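The compounds below may be only part of what the source reports. "The series", "measured", "known", "first", "only" and "open" are said of these compounds alone.

Measured in a functional assay on HCT-116 cells (Homo sapiens) for inhibition, read by sulforhodamine B assay, with a stated time of 48 h, tested at 50 uM; a lower number here means less inhibition of growth, a higher number more inhibition of growth at the concentration tested:
Compound 1 `COc1ccc([C@@H]2C/C(=N/OCc3cn(-c4ccc(C(=O)c5ccccc5)cc4)nn3)c3cc(CC=C(C)C)c(OC)cc3O2)cc1`: 52%
Compound 2 `COc1ccc([C@@H]2C/C(=N/OCc3cn(-c4ccc(C#N)cc4)nn3)c3cc(CC=C(C)C)c(OC)cc3O2)cc1`: 50%

Compound 2 stands at 50%, within the scatter of compound 1. Compound 3 `COc1ccc([C@@H]2C/C(=N/OCc3cn(-c4cccc(CO)c4)nn3)c3cc(CC=C(C)C)c(OC)cc3O2)cc1` carries 3-(hydroxymethyl)phenyl in place of 4-cyanophenyl on an aromatic nitrogen. Within the data shown here, only one measured step bears on this, and it concerns a different exchange: a number 2 percentage points lower from compound 1 to compound 2 (within the scatter), with cyano in place of benzoyl on an aromatic carbon. Among the measured compounds shown here, no measured compound carries hydroxymethyl, so the basis is thin, and no shift in this assay beyond the scatter is expected. The expected change is a number 2 percentage points lower from compound 2 to compound 3 (within the scatter). Compound 3 is estimated at 48%, within an expected range of 34% to 62%.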

Compound 3, percent growth inhibition at one concentration: 27%
Compound 3: middle estimate off by 21 percentage points, on the high side; measured number outside the range, below it.
By their numbers in this assay, from the lowest: compound 3; then compounds 2 and 1 (each within the scatter of the next).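

The exchange of 4-cyanophenyl for 3-(hydroxymethyl)phenyl on the aromatic nitrogen gives a number 23 percentage points lower from compound 2 to compound 3 (beyond the scatter) in this assay. Unlike the exchange of benzoyl for cyano, this step shows that the group on this nitrogen can change growth inhibition at the concentration tested. Nothing available explains this drop.

The compounds shown leave open whether the drop follows the hydroxymethyl group itself or its place on the phenyl ring, as the two change together. Going by these compounds, how an aminomethyl group or a carboxylic acid there would read in this assay also stays open.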